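The source may report more compounds than this note shows. Statements on the series, on what has been measured and on what is new or still open speak of the compounds shown alone.

Three compounds share a core in which a saturated ring holding a basic nitrogen is attached to an aromatic six-membered ring that carries a halogen. Compound 1 `Clc1cncc(N2CCCNCCC2)c1` is tested in a functional assay on HEK293 cells for agonist activity at Neuronal acetylcholine receptor; alpha4/beta2 (Homo sapiens), read by FLIPR and calcium flux (a higher number here means that more compound is needed for the effect, a lower number that less compound is needed), where compound 1 gives 170 nM. Compound 2 `Oc1cc(N2CCCNCC2)cnc1I` gives 479 nM in this assay, and compound 3 `Brc1ccc(N2CCNCC2)cn1` gives 2510 nM. Compound 1 therefore stands at the lowest of the three numbers: compound 2 lies beyond the usual scatter above it, and compound 3 lies well beyond that scatter, so compound 1 is the most potent of the three shown.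

Compound 4 `Brc1cncc(N2CCCNCCC2)c1` is not yet measured. It differs from compound 1 in a single place: bromo in place of chloro on an aromatic carbon. Within the data shown here, no pair of measured compounds here differs only in this way, so nothing among the measured values shows what a bromo in place of a chloro does on this core. In the absence of such a comparison, the step of a 1.1-fold lower number from compound 1 to compound 4 (0.05 log units; within the scatter) is expected to stay within the usual scatter, with no clear direction. On that basis compound 4 is estimated at 150 nM, with a range from 60 nM to 400 nM.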

Compound 4, half-maximal effective concentration: 182 nM
Estimate against measurement, compound 4: 1.2-fold (0.08 log units) below, within the range that was stated.
By their numbers in this assay, from the lowest: compounds 1 and 4 (each within the scatter of the next); then compound 2; then compound 3.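

Among these compounds, this is the only pair here that differs in one place, and in this assay bromo in place of chloro on this aromatic carbon, two atoms from the ring nitrogen, gives a 1.1-fold higher number from compound 1 to compound 4 (0.03 log units; within the scatter) and so lies within the scatter. Among the compounds shown here, on the shared core, then, these two halogens cannot be told apart at this position, something the earlier compounds could not show, as they differ from one another in more than one place. No measurement of any property of the two groups is available to go with this result.

The compounds shown leave open what a different kind of group on this same carbon would do, such as the smaller halogen fluoro, a methoxy, a nitrile or an amine. They also leave open whether bromo and chloro would match in the same way on a core with a different saturated ring, such as that of compound 3, as this single pair speaks only for the core of compound 1.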